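This account rests on a few compounds, and the source may have more. Where it says the series, first, only, none or still open, it means among the compounds named here.

The series shares one core, shown for compound 1 as `C=C1C[C@]23C[C@@]1(O)CC[C@H]2c1ccc(OS(=O)(=O)c2ccc(C)cc2)c(C)c1[C@@H]3Cn1cc(-c2ccc(Br)cc2)nn1`, for compound 2 as `C=C1C[C@]23C[C@@]1(O)CC[C@H]2c1cc(Br)c(O)c(C)c1[C@@H]3Cn1cc(-c2ccc(C)cc2)nn1` and for compound 3 as `C=C1C[C@]23C[C@@]1(O)CC[C@H]2c1cc(Br)c(O)c(C)c1[C@@H]3Cn1cc(-c2ccccn2)nn1`; the unmeasured member, compound 4, is `C=C1C[C@]23C[C@@]1(O)CC[C@H]2c1cc(Br)c(O)c(C)c1[C@@H]3Cn1cc(-c2ccc(Cl)cc2)nn1`. In a functional assay on A549 cells (Homo sapiens) for cytotoxicity, read by MTT assay, with a stated time of 4 days (on this read-out higher numbers stand for weaker inhibition and lower numbers for stronger inhibition), compound 1 reaches only the limit of the assay, > 20000 nM. Compound 2 likewise gives only the limit, > 20000 nM. Compound 3 too stands at the limit, > 20000 nM, so no number is known for it, and the two further values shown are limits as well. Among the measured compounds shown here, the only step among measured compounds, a step that the two limits leave unreadable from compound 2 to compound 3, cannot be read in size, because both of its ends rest on (the limit of > 20000 nM in this assay, at which 3 of the 3 values shown sit).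

The change leading to compound 4 is 4-chlorophenyl in place of pyridin-2-yl on an aromatic carbon. For the measured compounds named here, no measured step bears on it with a readable size: the change from compound 2 to compound 3 is the closest comparison, and it is unreadable. With three members at the limit, there is no ground to expect a move in this assay beyond the scatter, in either direction. Compound 4 is therefore estimated to sit at 30000 nM, within a range of 12000 nM to 80000 nM, which means an expected step that the limit leaves unreadable from compound 3 to compound 4.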

Compound 4, half-maximal inhibitory concentration: 10500 nM
Beside the measured number, compound 4's estimate is 2.9-fold (0.46 log units) above it, and the stated range ends above it.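

Compound 4 is the only member shown that gives a number rather than a limit in this assay, where compound 4 gives 10500 nM, so a substituent at this place on the five-membered aromatic ring with 3 nitrogen can give the series a readable number. Putting 4-chlorophenyl in place of pyridin-2-yl gives an at least 1.9-fold lower number from compound 3 to compound 4 (0.27 log units; that floor lies within the scatter), and chloro in place of methyl gives an at least 1.9-fold lower number from compound 2 to compound 4 (0.27 log units; that floor lies within the scatter). Neither step is more than a floor, and the real size of each stays unknown, as one end of each rests on a limit: the limit of > 20000 nM in this assay, at which 3 of the 4 values shown sit.

The step between compound 2 and compound 3 cannot be read, so the series gives no order among the 4-methylphenyl and pyridin-2-yl compounds, and a single readable value cannot show whether the chloro group itself is what matters. On these data alone, it also remains open how the number would move with fluoro, methoxy, an amine or a carboxylic acid in place of the chloro on that phenyl ring.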